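Swapping a Phenol for a Propylsulfonamide

The source may report more compounds than this note shows. Statements on the series, on what has been measured and on what is new or still open speak of the compounds shown alone.

Compound 1 `Oc1cccc2c1CCCC2c1c[nH]cn1` was tested in an assay on isolated protein (Cricetulus griseus) for binding affinity to Alpha-1B adrenergic receptor (Mesocricetus auratus), read by radioligand binding (on this read-out lower numbers stand for stronger inhibition and higher numbers for weaker inhibition), where compound 1 gives 145 nM. For the measured compounds named here, of the two numbers measured so far, this is the lower one; the nearest is compound 3 `CCS(=O)(=O)Nc1cc(C2CCCCC2)cc2c1CCCC2c1c[nH]cn1`, which carries an (ethylsulfonyl)amino group and a cyclohexyl group and gives 891 nM, a gap beyond the usual scatter. For compound 2 `CS(=O)(=O)Nc1ccc(Cl)c2c1CCCC2c1c[nH]cn1` the this assay result is only a limit, < 10000 nM, not a number. Compound 4 `CCCS(=O)(=O)Nc1cccc2c1CCCC2c1c[nH]cn1` is not yet measured; it differs from compound 1 in one place: (propylsulfonyl)amino in place of hydroxy on an aromatic carbon. Going by the values given here, no pair of measured compounds differs by a single change, so the expectation rests on compound 3, whose 891 nM hints at a moderate weakening when a sulfonamide replaces the hydroxy. Compound 4 is therefore expected to give 500 nM, within 150 nM to 2000 nM. The expected step is a 3.4-fold higher number from compound 1 to compound 4 (0.54 log units; beyond the scatter).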

Compound 4, inhibition constant: < 10000 nM
Compound 4 was reported as a limit (the forecaster's own chance of this, stated with the estimate: 10%); the middle value lies beyond the limit too.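

In this assay compound 4 gives < 10000 nM, which is a limit and not a number, so its step from compound 1 cannot be read. The compounds shown leave open how far (propylsulfonyl)amino in place of hydroxy shifts the number.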